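A few compounds are considered here, and "the series" means these few. Any claim that something is new, unique, unknown or untested is made for them only; others in the source may bear on it.

In a functional assay on HCT-116 cells (Homo sapiens) for antiproliferative activity, read by MTT assay, with a stated time of 72 h (on this read-out lower numbers stand for stronger inhibition and higher numbers for weaker inhibition), three compounds with a shared core have been measured. Compound 1 `C#Cc1ccc(NC(=O)CCc2cccc3c2B(O)OC3)cc1` gives 45000 nM, compound 2 `CC(C)(C)c1ccc(NC(=O)CCc2cccc3c2B(O)OC3)cc1` gives 19000 nM, and compound 3 `CC(C)(C)OC(=O)NCc1ccc(NC(=O)CCc2cccc3c2B(O)OC3)cc1` gives 2300 nM, the lowest of the three. The next structure, compound 4 `CCOC(=O)c1ccc(NC(=O)CCc2cccc3c2B(O)OC3)cc1`, has ethoxycarbonyl in place of ((tert-butoxycarbonyl)amino)methyl on an aromatic carbon. For the measured compounds named here, two measured steps bear on this swap, since both end at the group that compound 4 gives up: a modest one, an 8.3-fold lower number from compound 2 to compound 3 (0.92 log units; beyond the scatter), and a large one, a 20-fold lower number from compound 1 to compound 3 (1.29 log units; beyond the scatter). From the compounds shown here alone, neither other group matched compound 3, so a modest rise in the number is expected in this assay, though ethoxycarbonyl itself is untested. The estimated change is a 4.3-fold higher number from compound 3 to compound 4 (0.64 log units; beyond the scatter). Compound 4 is expected at 10000 nM, within a range of 2500 nM to 40000 nM.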

Compound 4, half-maximal inhibitory concentration: > 100000 nM
Compound 4: no number, only a limit; the forecaster's own chance of this, stated with the estimate: 5%; at least 10-fold (1.00 log units) between middle value and limit.
By their numbers in this assay, from the lowest: compound 3; then compound 2; then compound 1. At a limit, above all of these: compound 4.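

In this assay compound 4 has only a limit, not a number: the limit of > 100000 nM in this assay, at which 1 of the 4 values shown sits. At this position, ethoxycarbonyl sits behind all three other groups, with an at least 43-fold higher number from compound 3 to compound 4 (1.63 log units; beyond the scatter), an at least 5.2-fold higher number from compound 2 to compound 4 (0.72 log units; beyond the scatter) and an at least 2.2-fold higher number from compound 1 to compound 4 (0.34 log units; beyond the scatter). The leaving and entering groups have the same count of hydrogen-bond acceptors, so that count alone does not set the result in this pair.

From the compounds shown here alone, how far each step really reaches remains open. So does whether a free aminomethyl group or a carboxylic acid at this position would give a measurable number.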